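Formyl for Bromo on Two Related Fused Cores

The source may hold more compounds than are shown below. What is called first, only, known or untested is meant among the compounds shown, and "the series" means these compounds.

Three compounds were measured in an ADME assay on CCRF-CEM cells (Homo sapiens) for cytotoxicity, with a stated time of 72 h; a lower number here means a stronger inhibitor, a higher number a weaker inhibitor. Compound 1 `Clc1ccc(Cc2nn3c(Br)c(-c4ccc(Cl)cc4Cl)nc3s2)cc1` gives 106000 nM, compound 2 `O=c1oc2ccccc2cc1-c1nc2sc(Cc3ccc(Cl)cc3)nn2c1Br` gives 3700 nM, and compound 3 `O=Cc1c(-c2ccc(Cl)cc2Cl)nc2sc(Cc3ccc(Cl)cc3)nn12` gives 79000 nM. Compound 2 stands lowest of the three, and both other numbers lie beyond the scatter above it. Compounds 1 and 3 differ in one place, (formyl in place of bromo on an aromatic carbon), and that step is a 1.3-fold lower number from compound 1 to compound 3 (0.13 log units; within the scatter). How the core of compound 2 differs from the core of compound 1 is not broken down here.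

Compound 4 `O=Cc1c(-c2cc3ccccc3oc2=O)nc2sc(Cc3ccc(Cl)cc3)nn12` is not yet measured in this assay. It differs from compound 2 by formyl in place of bromo on an aromatic carbon. This is the same kind of change as that between compounds 1 and 3, though the surroundings are not identical: in compound 1 the changed carbon is next to the ring atom that bears a 2,4-dichlorophenyl group, whereas in compound 2 it is next to the ring atom that bears a large group. Because a 1.3-fold lower number from compound 1 to compound 3 (0.13 log units; within the scatter) stayed within the scatter, a similarly small step is expected for compound 4, namely a 1.2-fold lower number from compound 2 to compound 4 (0.06 log units; within the scatter). Compound 4 is therefore estimated at 3200 nM, between 1200 nM and 9000 nM in this assay.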

Compound 4, half-maximal inhibitory concentration: 750 nM
For compound 4 the middle estimate is 4.3-fold (0.63 log units) above the measured one; measured number outside the range, below it.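

In this assay, formyl in place of bromo on an aromatic carbon gives a 4.9-fold lower number from compound 2 to compound 4 (0.69 log units; beyond the scatter), so on this core the change has an effect that can be told apart from the scatter. The same change does not carry over at the same size from one core to the other: the same change on two cores in this assay, a 1.3-fold lower number (0.13 log units; within the scatter) from compound 1 to compound 3 and a 4.9-fold lower number (0.69 log units; beyond the scatter) from compound 2 to compound 4, 3.7-fold (0.57 log units) apart, beyond the scatter of two such steps What this shows is that, within these two pairs, the size of the step cannot simply be transferred between cores; it does not show which structural difference between the pairs accounts for the gap, and two pairs give no general rule for the series.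

The compounds shown leave open how a hydroxymethyl group, a carboxylic acid or a nitrile on that same aromatic carbon would compare with formyl and bromo in this assay. They also leave open what size the step would take on a third core, for instance one carrying an unsubstituted phenyl in place of the 2,4-dichlorophenyl group.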